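Acetyl capping of the hydroxy group on compound 3

The compounds below may be only part of what the source reports. "The series", "measured", "known", "first", "only" and "open" are said of these compounds alone.

Compound 1 `NC(=O)c1c[nH]c([C@@H](O)c2ccccc2)cc1=O` is the parent of the series. In a functional assay on HeLa cells (Homo sapiens) for inhibition, read by sulforhodamine B assay, with a stated time of 48 h (on this read-out lower numbers stand for stronger inhibition and higher numbers for weaker inhibition), compound 1 returns only a limit of the assay, > 50000 nM. Compound 2 `CC(C)CC(=O)NC(=O)c1c[nH]c([C@@H](O)c2ccccc2)cc1=O` carries isobutylcarbonyl in place of hydrogen on an amide-type nitrogen. In this assay compound 2 also returns only a limit, > 50000 nM. Compound 3 `NC(=O)c1cn(CCO)c([C@@H](O)c2ccccc2)cc1=O` carries 2-hydroxyethyl in place of hydrogen on an aromatic nitrogen. In this assay compound 3 likewise returns only a limit, > 50000 nM. The steps a step that the two limits leave unreadable from compound 1 to compound 2 and a step that the two limits leave unreadable from compound 1 to compound 3 therefore cannot be sized, since every value shown sits at the limit of > 50000 nM in this assay, at which 3 of the 3 values shown sit. Compound 3 thus stands at the limit, with no number to place it against the others.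

Compound 4 `CC(=O)O[C@@H](c1ccccc1)c1cc(=O)c(C(N)=O)cn1CCO` differs from compound 3 by acetyl in place of hydrogen on an oxygen on a saturated carbon; cut one bond further out this reads hydroxy to acetoxy. Among the measured compounds shown here, no measured step bears on this change, and the two steps that exist are unreadable. The step from compound 3 to compound 4 is expected to be a step that the limit leaves unreadable from compound 3 to compound 4, meaning no readable shift. Compound 4 is therefore expected to remain at the limit, estimated at 60000 nM with a range of 20000 nM to 200000 nM.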

Compound 4, half-maximal inhibitory concentration: > 50000 nM
Compound 4: a limit, no number (the forecaster's own chance of this, stated with the estimate: 80%); the middle value lies beyond the limit too.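

In this assay compound 4 gives only a limit, > 50000 nM, so the change from compound 3 to compound 4 cannot be read as a step: the limit of > 50000 nM in this assay, at which 4 of the 4 values shown sit. The compounds shown leave open how large the hydroxy to acetoxy change is, and whether any change on the shared core gives a measurable value.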